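Diethylamino for Dimethylamino on a Longer Chain

The source may hold more compounds than are shown below. What is called first, only, known or untested is meant among the compounds shown, and "the series" means these compounds.

Compound 1 `CN(C)CCn1c(N)c(-c2nc3ccccc3n2C)c2nc(C#N)c(C#N)nc21` and compound 2 `CCN(CC)CCn1c(N)c(-c2nc3ccccc3n2C)c2nc(C#N)c(C#N)nc21` share a core. In a functional assay on cells (Homo sapiens) for antiproliferative activity, read by MTT assay, with a stated time of 48 h (a lower number here means a stronger inhibitor, a higher number a weaker inhibitor), compound 1 reaches only the limit of > 50000 nM. Compound 2 likewise gives only the limit of > 50000 nM in this assay. The change between them is diethylamino in place of dimethylamino on a saturated chain carbon, two bonds along the chain from an aromatic nitrogen, and the step that the two limits leave unreadable from compound 1 to compound 2 cannot be read because of the limit of > 50000 nM in this assay, at which 2 of the 3 values shown sit. Compound 3 `CN(C)CCCn1c(N)c(-c2nc3cc(Cl)ccc3[nH]2)c2nc(C#N)c(C#N)nc21` has a different core; the difference between the two cores is not broken down here. In this assay compound 3 gives 28100 nM. Compound 4 `CCN(CC)CCCn1c(N)c(-c2nc3cc(Cl)ccc3[nH]2)c2nc(C#N)c(C#N)nc21` carries the same kind of change, (diethylamino in place of dimethylamino on a saturated chain carbon, three bonds along the chain from an aromatic nitrogen), but here the place is three bonds along the chain from an aromatic nitrogen rather than two. With no readable step from compound 1 to compound 2 to lean on, compound 4 is expected to sit near compound 3, with an estimated step of a 1.1-fold higher number from compound 3 to compound 4 (0.03 log units; within the scatter). Compound 4 is thus estimated at 30000 nM, somewhere between 10000 nM and 80000 nM.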

Compound 4, half-maximal inhibitory concentration: 23200 nM
Compound 4: middle estimate off by 1.3-fold (0.11 log units), on the high side; the measured number falls inside the stated range.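

In this assay, the change from dimethylamino to diethylamino on the core of compound 3 gives a 1.2-fold lower number from compound 3 to compound 4 (0.08 log units; within the scatter) and so the two amines cannot be told apart on this core. The same change on the core of compound 1 cannot be read, because compound 1 and compound 2 both stand at a limit and not at a number: the limit of > 50000 nM in this assay, at which 2 of the 4 values shown sit. The pair of compound 3 and compound 4 therefore shows the change to be without a readable effect on one core only, and it does not show whether that result carries over to the other core.

Going by these compounds, it remains open whether a piperidine or a morpholine in place of diethylamino would give a step beyond the scatter on the core of compound 3. On these data alone, a chain longer than 3-(diethylamino)propyl is equally open.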